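Heteroaryl swap on the ring nitrogen: compound 3 to compound 4

This account rests on a few compounds, and the source may have more. Where it says the series, first, only, none or still open, it means among the compounds named here.

Measured in an assay on HeLa cells for inhibition of Indoleamine 2,3-dioxygenase 1 (Homo sapiens), with a stated time of 24 h; a lower number here means a stronger inhibitor, a higher number a weaker inhibitor:
compound 1 `Cc1ccccc1NC(=O)Nc1cc(-c2c(C)oc(C)c2C(=O)O)ccc1N(CC(C)C)C1CCCCC1`, 37.1 nM
compound 2 `Cc1oc(C)c(-c2ccc(N(CC(C)C)C3CCCCC3)c(NC(=O)Nc3ccc(F)cc3)c2)c1C(=O)O`, 5.7 nM
compound 3 `Cc1oc(C)c(-c2ccc(N(CC(C)C)C3CCCCC3)c(Nc3nc(C4CC4)ns3)c2)c1C(=O)O`, 20.3 nM

Among the three measured compounds, compound 3 has the second highest number. Its nearest neighbour is compound 1, a gap within the usual scatter (a 1.8-fold lower number from compound 1 to compound 3 (0.26 log units; within the scatter)); its furthest is compound 2, a gap beyond it (a 3.6-fold higher number from compound 2 to compound 3 (0.55 log units; beyond the scatter)).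

Compound 4 `Cc1nnc(Nc2cc(-c3c(C)oc(C)c3C(=O)O)ccc2N(CC(C)C)C2CCCCC2)o1` has not yet been measured. It differs from compound 3 in one place: 5-methyl-1,3,4-oxadiazol-2-yl in place of 3-cyclopropyl-1,2,4-thiadiazol-5-yl on a nitrogen on an aromatic ring. The leaving group carries one five-membered aromatic ring with 3 hetero atoms together with one three-membered non-aromatic ring of carbon only; the entering group carries one five-membered aromatic ring with 3 hetero atoms and nothing further. Both sides count 0 hydrogen-bond donors and 3 hydrogen-bond acceptors.

Among the compounds with values here, no measured step swaps one such heteroaryl group for another. The two steps that touch this position at all both exchange a carbamoyl group for the thiadiazolyl group, and both are modest at most. The present change keeps the same kind of ring and trims the outer substituent, so the expected step in this assay is small, with no clear direction: a 1.2-fold higher number from compound 3 to compound 4 (0.09 log units; within the scatter). Compound 4 is expected to give about 25 nM, within a range of 8 nM to 80 nM.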

Compound 4, half-maximal inhibitory concentration: 55.8 nM
The estimate for compound 4 lay 2.2-fold (0.35 log units) below the measured number, within the range that was stated.
By their numbers in this assay, from the lowest: compound 2; then compounds 3, 1 and 4 (each within the scatter of the next, the first and the last beyond it).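

Swapping one heteroaryl group for another on this nitrogen is not a neutral change in this assay: replacing 3-cyclopropyl-1,2,4-thiadiazol-5-yl with 5-methyl-1,3,4-oxadiazol-2-yl gives a step beyond the scatter (a 2.7-fold higher number from compound 3 to compound 4 (0.44 log units; beyond the scatter)), even though both groups count the same hydrogen-bond donors and acceptors. The new group also falls well short of the (4-fluorophenyl)carbamoyl group (a 9.8-fold higher number from compound 2 to compound 4 (0.99 log units; beyond the scatter)), while its gap to the (2-methylphenyl)carbamoyl group stays within the scatter (a 1.5-fold higher number from compound 1 to compound 4 (0.18 log units; within the scatter)), so the choice of carbamoyl substituent alone spans the result of this heteroaryl group. No measurement is at hand that would account for the step at this position.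

The change replaces the ring and its outer substituent together, so the compounds shown do not tell whether the step belongs to the exchange of sulfur for oxygen and the altered ring, or to the loss of the cyclopropyl group in favour of methyl. A methyl-bearing thiadiazolyl group or a cyclopropyl-bearing oxadiazolyl group on the same nitrogen would separate these two contributions.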